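Bromo Substitution Tested on a Second Core

The compounds below may be only part of what the source reports. "The series", "measured", "known", "first", "only" and "open" are said of these compounds alone.

Compound 1 `O=C1N=C(N2N=C(c3ccccc3)CC2c2ccccc2O)S/C1=C1/C(=O)Nc2ccccc21` and compound 2 `O=C1N=C(N2N=C(c3ccccc3)CC2c2ccccc2O)S/C1=C1/C(=O)Nc2ccc(Br)cc21` share one core. In a functional assay on cells (Cancer cell lines, Homo sapiens) for cytotoxicity, read by sulforhodamine B assay, with a stated time of 48 h (on this read-out higher numbers stand for weaker inhibition of growth and lower numbers for stronger inhibition of growth), compound 1 gives 4770 nM, while compound 2 gives 800 nM. The change between them is bromo in place of hydrogen on an aromatic carbon, and it made a 6.0-fold lower number from compound 1 to compound 2 (0.78 log units; beyond the scatter). Compound 3 `COc1ccc(C2=NN(C3=NC(=O)/C(=C4\C(=O)Nc5ccccc54)S3)C(c3ccc(Cl)cc3)C2)cc1` carries a different core; the difference between the two cores is not broken down here. In this assay compound 3 gives 100000 nM, the highest of the three numbers. Compound 4 `COc1ccc(C2=NN(C3=NC(=O)/C(=C4\C(=O)Nc5ccc(Br)cc54)S3)C(c3ccc(Cl)cc3)C2)cc1` has not yet been measured in this assay. It differs from compound 3 by bromo in place of hydrogen on an aromatic carbon, the same change as that from compound 1 to compound 2. Because that change made a 6.0-fold lower number from compound 1 to compound 2 (0.78 log units; beyond the scatter) on the other core, a step in the same direction is expected here. Compound 3 starts far weaker, and the step from it is expected to be a 4.0-fold lower number from compound 3 to compound 4 (0.60 log units; beyond the scatter). Compound 4 is therefore estimated at 25000 nM, between 8000 nM and 100000 nM.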

Compound 4, concentration for total growth inhibition: 400 nM
The estimate for compound 4 lay 63-fold (1.80 log units) above the measured number, outside the stated range (below it).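

In this assay, bromo in place of hydrogen on an aromatic carbon gave a 250-fold lower number from compound 3 to compound 4 (2.40 log units; beyond the scatter), so the number fell on both cores, but the size of the step did not carry over: the same change on two cores in this assay, a 6.0-fold lower number (0.78 log units; beyond the scatter) from compound 1 to compound 2 and a 250-fold lower number (2.40 log units; beyond the scatter) from compound 3 to compound 4, 42-fold (1.62 log units) apart, beyond the scatter of two such steps

The direction of the change held on the two cores shown, while the step on one core gave no reliable measure of the step on the other. Two pairs do not establish a rule for the series, and they do not show which difference between the cores goes with the gap.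

The compounds shown leave open whether a fluoro group, an amine or a carboxylic acid on that same aromatic carbon would follow the bromo. They also leave open how the bromo step would behave on any further core.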